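The source may report more compounds than this note shows. Statements on the series, on what has been measured and on what is new or still open speak of the compounds shown alone.

Measured so far in an assay on isolated protein for inhibition of Calpain-1 catalytic subunit (Sus scrofa); a lower number here means a stronger inhibitor, a higher number a weaker inhibitor:
compound 1, `O=C(O)/C(S)=C/c1c[nH]c2c(Cl)cccc12`, gives 90 nM
compound 2, `O=C(O)/C(S)=C/c1c[nH]c2cc(Br)ccc12`, gives 90 nM
compound 3, `O=C(O)/C(S)=C/c1c[nH]c2cc(I)ccc12`, gives 300 nM

On these numbers compound 1 stands level with compound 2 at the digits printed, and the two together hold the lowest of the three numbers. Within the data shown here, compound 3 stands furthest from compound 1: compound 1 gives 90 nM where compound 3 gives 300 nM, and the only single-place step among the measured compounds, a 3.3-fold higher number from compound 2 to compound 3 (0.52 log units; beyond the scatter), accounts for that gap.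

Compound 4, `O=C(O)/C(S)=C/c1c[nH]c2c(Br)cccc12`, differs from compound 1 in one place: bromo in place of chloro on an aromatic carbon. Among the measured compounds shown here, no measured pair shows exactly this change at this place. The step that comes nearest is a 3.3-fold higher number from compound 2 to compound 3 (0.52 log units; beyond the scatter), a halogen swap at a different place on the same core, which moved the number modestly and in the weaker direction. Against that, compound 1 with chloro and compound 2 with bromo, each at its own place, give the same number. The swap of chloro for bromo is therefore expected to leave the number roughly where compound 1 sits, with the step of a 1.1-fold higher number from compound 1 to compound 4 (0.05 log units; within the scatter) expected to fall within the scatter. Compound 4 is estimated at 100 nM, within a range of 40 nM to 250 nM.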

Compound 4, half-maximal inhibitory concentration: 70 nM
Beside the measured number, compound 4's estimate is 1.4-fold (0.15 log units) above it; low and high end bracket the measured number.
By their numbers in this assay, from the lowest: compounds 4, 1 and 2 (each within the scatter of the next); then compound 3.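

At this place, on an aromatic carbon of a six-membered aromatic ring of carbon only, ortho to a fused ring, this assay shows a 1.3-fold lower number from compound 1 to compound 4 (0.11 log units; within the scatter) for bromo in place of chloro, so this position does not separate the two halogens. Among these compounds, the earlier compounds held only one halogen swap, a 3.3-fold higher number from compound 2 to compound 3 (0.52 log units; beyond the scatter) for iodo in place of bromo at a different place, and that step lies beyond the scatter whereas the new one lies within it; since both the halogens and the place differ, the two steps cannot be set side by side as a rule about the series. Nothing measured here accounts for either step.

Going by these compounds, whether iodo at this same place would leave the number within the scatter, or would raise it as it did at the other place, remains open. So does the question of how far this position tolerates groups that are not halogens, such as a methoxy group, an amine or a carboxylic acid, or a plain hydrogen in place of the halogen.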